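A few compounds are considered here, and "the series" means these few. Any claim that something is new, unique, unknown or untested is made for them only; others in the source may bear on it.

Working notes on the series, read in a functional assay on SW620/5-FU cells (Homo sapiens) for cytotoxicity, read by MTT assay, with a stated time of 48 h, in the presence of a further agent that is not named here; on this read-out higher numbers stand for an effect only at larger amounts of compound and lower numbers for an effect already at smaller amounts. Compound 1 (`Cn1nc(C(F)(F)F)c2c(-c3ccccc3)cc(NNC(=O)Nc3cc(Cl)nc(Cl)c3)nc21`) gives 13100 nM, compound 3 (`CC(C)c1cc(NNC(=O)Nc2cc(Cl)nc(Cl)c2)nc2c1c(C(F)(F)F)nn2C`) gives 19100 nM, and compound 2 (`COc1cc(NC(=O)NNc2cc(-c3ccc(F)cc3)c3cnn(C)c3n2)cc(OC)c1OC`) gives 39200 nM, the highest number of the three. Isopropyl in place of phenyl on an aromatic carbon gives a 1.5-fold higher number from compound 1 to compound 3 (0.16 log units; within the scatter). Compound 3 therefore shares the lower end of this small range, and compound 2 lies clear above it.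

The next change leads to compound 4 (`CC(C)c1cc(NNC(=O)Nc2cc(Cl)nc(Cl)c2)nc2c1cnn2C`): hydrogen in place of trifluoromethyl on an aromatic carbon. Among the compounds with values here, no measured step isolates this change. Within the data shown here, the only step available, a 1.5-fold higher number from compound 1 to compound 3 (0.16 log units; within the scatter), involves a different group and gives no direct measure of it. Compound 2, at 39200 nM, also lacks trifluoromethyl, but it differs from compound 3 in other groups too, so it offers only a weak hint towards a higher number. No step beyond the scatter is therefore expected in this assay, with a slight lean upwards. The estimated change is a 1.3-fold higher number from compound 3 to compound 4 (0.12 log units; within the scatter). For compound 4 the expected value is 25000 nM, with an estimated range from 10000 nM to 60000 nM.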

Compound 4, half-maximal effective concentration: 50100 nM
Beside the measured number, compound 4's estimate is 2.0-fold (0.30 log units) below it; the measured number falls inside the stated range.
By their numbers in this assay, from the lowest: compounds 1 and 3 (each within the scatter of the next); then compounds 2 and 4 (each within the scatter of the next).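

In this assay, within the data shown here, hydrogen in place of trifluoromethyl on an aromatic carbon of the five-membered ring gives a 2.6-fold higher number from compound 3 to compound 4 (0.42 log units; beyond the scatter), the first step between two measured compounds here that lies beyond the scatter. Among these compounds, the only earlier step, a 1.5-fold higher number from compound 1 to compound 3 (0.16 log units; within the scatter), was made at another place and stayed within the scatter, so the earlier compounds showed no clear response to a single change, while this pair shows that the number does respond to what stands on this carbon, at least with isopropyl elsewhere on the core. No measurement at hand accounts for this step.

The compounds shown leave open whether a step of this size also appears with phenyl in place of isopropyl on the core, since this change is read on one pair only. They also leave open whether trifluoromethyl itself matters or any group on this carbon would keep the lower number: a methyl, a chlorine or a nitrile there would separate these two readings.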